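Bromopropoxy Analogue in the Oxime Imidazolium Series: Lipophilicity Outlook

The compounds below may be only part of what the source reports. "The series", "measured", "known", "first", "only" and "open" are said of these compounds alone.

Measured compounds and values:
compound 1 `COCCOCn1cc[n+](C)c1/C=N/O`, -2.81
compound 2 `COC(C)CCOCn1cc[n+](C)c1/C=N/O`, -2.22
compound 3 `C[n+]1ccn(CCCCC#N)c1/C=N/O`, -2.8

All three share the same charged oxime core and differ only in the chain on the ring nitrogen. In a physicochemical assay for lipophilicity (on this read-out higher numbers stand for higher lipophilicity and lower numbers for lower lipophilicity), compound 3 gives -2.8, the second highest of the three numbers; compound 1 lies nearest, and only compound 2 is separated from it beyond the scatter. The step of a number 0.01 log units higher from compound 1 to compound 3 (within the scatter) shows that exchanging one five-atom chain for another of the same count left this assay essentially unchanged. Among the compounds with values here, the step of a number 0.59 log units higher from compound 1 to compound 2 (beyond the scatter) is the only step in the set that moved this assay, and it came with added carbon.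

Compound 4 `C[n+]1ccn(COCCCBr)c1/C=N/O` carries 3-bromopropoxy in place of 3-cyanopropyl on a saturated chain carbon bound to an aromatic nitrogen. Neither measured step covers this exact exchange. The step from compound 1 to compound 3 bears on it most directly and was within the scatter; the step from compound 1 to compound 2 sets the size that a real change in this assay has reached so far. A step of comparable or smaller size in this assay is expected, upward, a number 0.40 log units higher from compound 3 to compound 4 (beyond the scatter). For compound 4 the estimate is -2.4, within -2.9 to -1.9.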

Compound 4, distribution coefficient: -1.76
Compound 4: middle estimate off by 0.64 log units, on the low side; measured number above the stated range.
By their numbers in this assay, from the lowest: compounds 1 and 3 (each within the scatter of the next); then compound 2; then compound 4.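

At the saturated chain carbon bound to an aromatic nitrogen, 3-bromopropoxy in place of 3-cyanopropyl gives, in this assay, a number 1.04 log units higher from compound 3 to compound 4 (beyond the scatter), so two chains of 5 heavy atoms, each with 1 hydrogen-bond acceptor, can still sit far apart on this read-out, and matching those counts does not fix the number. Two bonds along the chain from the oxygen on a saturated carbon, bromomethyl in place of methoxy gives a number 1.05 log units higher from compound 1 to compound 4 (beyond the scatter), and bromomethyl in place of 1-methoxyethyl gives a number 0.46 log units higher from compound 2 to compound 4 (beyond the scatter), which places compound 4 highest of the four and shows that the added carbon of compound 2 did not mark the upper end of the range at this position. Nothing at hand explains the size of these steps.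

The compounds shown leave open how the change divides between the terminal bromine and the chain oxygen, as no compound here carries one without the other in an otherwise matched chain. A 3-chloropropoxy chain and an unsubstituted propoxy chain on the same carbon would bear directly on that question.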